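The compounds below may be only part of what the source reports. "The series", "measured", "known", "first", "only" and "open" are said of these compounds alone.

Of the compounds shown here, three have so far been tested in a functional assay on MCF7 cells (Homo sapiens) for antiproliferative activity, read by MTT assay, with a stated time of 72 h; a higher number here means a weaker inhibitor, a lower number a stronger inhibitor. Compound 1 `O=c1c(CSC(=S)N2CCN(c3ccccc3)CC2)coc2ccccc12` gives > 30000 nM, which is a limit of the assay rather than a number. Compound 2 `CN1CCN(C(=S)SCc2coc3ccccc3c2=O)CC1` gives 22900 nM. Compound 3 `O=c1c(SC(=S)N2CCCCC2)coc2ccc(Cl)cc12` gives > 25000 nM, again a limit of the assay rather than a number. Within the data shown here, compound 2 thus stands as the only compound with a measured number; the other two readings are limits. Among the measured compounds shown here, the one step between compounds that differ in a single place runs from compound 1 to compound 2, where methyl takes the place of phenyl on an amine nitrogen in a ring, and it gives an at least 1.3-fold lower number from compound 1 to compound 2 (0.11 log units; that floor lies within the scatter).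

Compound 4 `O=c1c(CSC(=S)N2CCCCC2)coc2ccccc12` is not yet measured. It differs from compound 2 by piperidin-1-yl in place of 4-methylpiperazin-1-yl on a thiocarbonyl carbon. For the measured compounds named here, no measured step exchanges these two groups, so the step from compound 1 to compound 2 is the only guide, and it is small. Compound 3 also carries piperidin-1-yl, but it differs from compound 4 in more than one place. Its reading is a limit. In this assay the expected step is therefore a 1.3-fold higher number from compound 2 to compound 4 (0.12 log units; within the scatter), with a fair chance that only a limit is reported. For compound 4 the estimate is 30000 nM, between 12000 nM and 80000 nM.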

Compound 4, half-maximal inhibitory concentration: 1700 nM
Compound 4: middle estimate off by 18-fold (1.25 log units), on the high side; measured number outside the range, below it.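

In this assay, the group on the thiocarbonyl carbon turns out to matter a great deal, with a 13-fold lower number from compound 2 to compound 4 (1.13 log units; beyond the scatter). Among these compounds, the only earlier step, an at least 1.3-fold lower number from compound 1 to compound 2 (0.11 log units; that floor lies within the scatter), could not show this, since it changed only the group on an amine nitrogen in a ring and started from a limit of the assay. Here the whole ring changes: 4-methylpiperazin-1-yl, a six-membered non-aromatic ring with 2 hetero atoms, gives way to piperidin-1-yl, which has 1 hetero atom, and nothing measured here explains why this change gives so large a step.

A pyrrolidin-1-yl or morpholin-4-yl group on the same thiocarbonyl carbon would test whether this gain needs the piperidin-1-yl ring itself or only the absence of the methyl-bearing amine nitrogen. As far as these compounds go, compound 4 differs in more than one place from compound 3, whose reading of > 25000 nM is a limit of the assay and not a number, so it remains open whether piperidin-1-yl helps equally on other versions of the core.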